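This account rests on a few compounds, and the source may have more. Where it says the series, first, only, none or still open, it means among the compounds named here.

Measured compounds in the series:

Compound 1 `COC(=O)C1=C(C)NC(=O)NC1c1cccc([N+](=O)[O-])c1` gives 11700 nM in an assay on HEK293 cells for antagonist activity at Voltage-dependent L-type calcium channel subunit alpha-1C (Oryctolagus cuniculus), read by FLIPR; a higher number here means a weaker inhibitor, a lower number a stronger inhibitor.
Compound 2 `CC1=C(C(=O)OC(C)C)C(c2cccc([N+](=O)[O-])c2)NC(=O)N1` gives 58100 nM in this assay.
Compound 3 `COC(=O)C1=C(C(C)C)NC(=O)NC1c1cccc([N+](=O)[O-])c1` gives in this assay only a limit of the assay, > 100000 nM, and not a number.

Compound 3 therefore stands at the weak end of what has been measured: it sits at the limit of > 100000 nM in this assay, at which 1 of the 3 values shown sits, whereas compound 1 and compound 2 each return a number. The two measured steps both start from compound 1 and both weaken: a 5.0-fold higher number from compound 1 to compound 2 (0.70 log units; beyond the scatter), and an at least 8.5-fold higher number from compound 1 to compound 3 (0.93 log units; beyond the scatter).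

Compound 4 `COC(=O)C1=C(C(C)C)NC(=O)N(C(=O)C(C)C)C1c1cccc([N+](=O)[O-])c1` is not yet measured. It differs from compound 3 by isopropylcarbonyl in place of hydrogen on an amide-type nitrogen in a ring. Going by the values given here, no measured step touches this ring nitrogen, so neither of the two steps bears directly on the change; they show only that compound 3, the starting point, is already beyond the range in which a number is returned. Among the compounds with values here, with no step pointing toward a gain, no recovery of potency is expected, and the most likely outcome for compound 4 in this assay is again a limit rather than a number. The step from compound 3 to compound 4 is expected to be a step that the limit leaves unreadable from compound 3 to compound 4, that is, nothing beyond the scatter. Compound 4 is estimated at 150000 nM, with a range from 50000 nM to 500000 nM.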

Compound 4, half-maximal inhibitory concentration: 56600 nM
Estimate against measurement, compound 4: 2.7-fold (0.42 log units) above; measured number inside the range.
By their numbers in this assay, from the lowest: compound 1; then compounds 4 and 2 (each within the scatter of the next). At a limit, above all of these: compound 3.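

Going by these compounds alone, the ring nitrogen is a position that none of the earlier steps touched, and it accepts isopropylcarbonyl in place of hydrogen: in this assay, compound 4 gives 56600 nM, a number on the scale. Compound 3, its parent, stands only at a limit of the assay and not at a number: the limit of > 100000 nM in this assay, at which 1 of the 4 values shown sits. The change reads as an at least 1.7-fold lower number from compound 3 to compound 4 (0.24 log units; that floor lies within the scatter), so adding the group at this nitrogen brings no loss, but the true size of the gain stays unfixed and its printed floor alone does not establish a real improvement.

Going by these compounds, it remains open whether isopropylcarbonyl on this nitrogen acts the same way when the double-bonded ring carbon carries methyl, as in compound 1, where a number is available at the start of the step and its size could be read in full. The compounds shown also leave open whether the response at this nitrogen depends on the acyl group, for instance with a smaller acetyl, a longer straight-chain acyl, or an acyl chain ending in an amine.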